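Working notes: replacing ethoxycarbonyl with aminomethyl

The source may report more compounds than this note shows. Statements on the series, on what has been measured and on what is new or still open speak of the compounds shown alone.

Measured in an ADME assay on Vero cells (Chlorocebus sabaeus) for cytotoxicity, read by flow cytometry and propidium iodide staining, with a stated time of 72 h; a higher number here means a weaker inhibitor, a lower number a stronger inhibitor:
- compound 1 `CN(C)c1ccc(Nc2c(O)c(=O)c2=O)cc1`: 12900 nM
- compound 2 `CCOC(=O)c1ccc(Nc2c(O)c(=O)c2=O)cc1`: 21500 nM

In this assay compound 2 stands at 21500 nM, and compound 1 stands at 12900 nM. These two values lie within the scatter of each other, so neither can be ranked.

Compound 3 `NCc1ccc(Nc2c(O)c(=O)c2=O)cc1` has not been measured. It differs from compound 2 as follows: aminomethyl in place of ethoxycarbonyl on an aromatic carbon. In words, this is aminomethyl in place of ethoxycarbonyl on an aromatic carbon.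

Going by the values given here, only one measured step bears on this change: a 1.7-fold higher number from compound 1 to compound 2 (0.22 log units; within the scatter). That step exchanged dimethylamino for ethoxycarbonyl on an aromatic carbon and stayed within the scatter. Among the compounds with values here, no measured compound carries aminomethyl, and two values form a thin basis, so the range must stay wide.

No step beyond the scatter is expected in this assay, and the direction is poorly defined. The expected step is a 1.3-fold lower number from compound 2 to compound 3 (0.13 log units; within the scatter), which is a small estimated change. For compound 3 the estimated value is 16000 nM, with an expected range from 5000 nM to 50000 nM.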

Compound 3, half-maximal inhibitory concentration: 36600 nM
The estimate for compound 3 lay 2.3-fold (0.36 log units) below the measured number; the measured number falls inside the stated range.
By their numbers in this assay, from the lowest: compounds 1, 2 and 3 (each within the scatter of the next, the first and the last beyond it).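

In this assay, going by these compounds alone, aminomethyl on this aromatic carbon gives a 1.7-fold higher number from compound 2 to compound 3 (0.23 log units; within the scatter), so the exchange with ethoxycarbonyl adds no step that can be read, although the two groups differ in size and in their hydrogen-bond donor and acceptor counts. Compared with dimethylamino, the same group gives a 2.8-fold higher number from compound 1 to compound 3 (0.45 log units; beyond the scatter), a modest step and the first in the series to pass the scatter, which shows that a single exchange at this position can separate two compounds, whereas compounds 1 and 2 could not be ranked. No measurement on hand offers an explanation for this step.

The three compounds leave open whether the gap between compound 1 and compound 3 follows the carbon link between ring and nitrogen or the two methyl groups on the nitrogen, and a plain amino group or dimethylaminomethyl at this position would separate those two readings. Also open, going by these compounds, is how a carboxylic acid or a longer aminoalkyl chain such as aminoethyl would stand against compound 3 in this assay on the same core.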